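The source may report more compounds than this note shows. Statements on the series, on what has been measured and on what is new or still open speak of the compounds shown alone.

Compound 2 `Cc1cccc(C#Cc2ccc3c(n2)CCN(C)C3=O)c1` gives the lowest number of the three measured compounds in a functional assay on HEK293 cells for negative allosteric modulation of metabotropic glutamate receptor 5 (Homo sapiens), read by FLIPR and calcium flux; a lower number here means a stronger inhibitor, a higher number a weaker inhibitor: in this assay compound 2 gives 2.9 nM, while compound 1 `Cc1ccccc1C#Cc1ccc2c(n1)CCN(C)C2=O` gives 776 nM and compound 3 `CN1CCc2nc(C#Cc3ccc(Cl)cc3)ccc2C1=O` gives 352 nM. Those two gaps, a 270-fold lower number from compound 1 to compound 2 (2.43 log units; beyond the scatter) and a 120-fold higher number from compound 2 to compound 3 (2.08 log units; beyond the scatter), both lie beyond the scatter, as does a 2.2-fold lower number from compound 1 to compound 3 (0.34 log units; beyond the scatter). Compound 4 `Cc1cccc(C#Cc2ccc3c(n2)CCN(C(C)C)C3=O)c1` keeps the 3-methylphenyl of compound 2 and changes only the amide nitrogen: isopropyl in place of methyl on an amide-type nitrogen in a ring. Going by the values given here, none of the measured steps touches that position; all three vary the ring on the triple-bonded carbon, so they give no direct guide. With no contrary evidence, the step of a 2.1-fold higher number from compound 2 to compound 4 (0.32 log units; beyond the scatter) is expected to stay small. Compound 4 is therefore estimated at 6 nM, in the range 1.5 nM to 25 nM.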

Compound 4, half-maximal inhibitory concentration: 4.8 nM
Compound 4: the middle estimate sits 1.3-fold (0.10 log units) above what was measured; low and high end bracket the measured number.
By their numbers in this assay, from the lowest: compounds 2 and 4 (each within the scatter of the next); then compound 3; then compound 1.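

In this assay, going by these compounds alone, the change to isopropyl on the amide-type nitrogen gives a 1.7-fold higher number from compound 2 to compound 4 (0.22 log units; within the scatter) and so gives the first reading at this position. Here, the bulkier isopropyl leaves the number within the scatter, whereas a change on the triple-bonded carbon can move it much further, as in a 120-fold higher number from compound 2 to compound 3 (2.08 log units; beyond the scatter). Nothing shown explains this result. From the compounds shown here alone, it remains open whether a longer chain, an amine or a carboxylic acid on that nitrogen would be accepted in the same way. Going by these compounds, whether isopropyl would behave alike with 2-methylphenyl or 4-chlorophenyl on the triple-bonded carbon also remains open.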